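From Oxan-4-yl to Thian-4-yl on the Amine Nitrogen

A few compounds are considered here, and "the series" means these few. Any claim that something is new, unique, unknown or untested is made for them only; others in the source may bear on it.

Compound 3 `c1ccc2c(c1)CN[C@@H](CN(CCCCNC1CCOCC1)[C@H]1CCCc3cccnc31)C2` stands second of three measured compounds in a functional assay on cells for antagonist activity at C-X-C chemokine receptor type 4 (Homo sapiens), read by fluorescence and calcium flux, with stated times of 25 min and 90 s (a lower number here means a stronger inhibitor, a higher number a weaker inhibitor), giving 29.4 nM. Compound 1 `c1ccc(CNCCCCN(C[C@H]2Cc3ccccc3CN2)[C@H]2CCCc3cccnc32)cc1` gives 20.1 nM, and the gap a 1.5-fold higher number from compound 1 to compound 3 (0.17 log units; within the scatter) lies within the scatter. Compound 2 `c1ccc2c(c1)CN[C@@H](CN(CCCCNCC1CCCCC1)[C@H]1CCCc3cccnc31)C2` gives 158 nM, and the step of a 5.4-fold lower number from compound 2 to compound 3 (0.73 log units; beyond the scatter) is modest. Compound 4 `c1ccc2c(c1)CN[C@@H](CN(CCCCNC1CCSCC1)[C@H]1CCCc3cccnc31)C2` differs from compound 3 in one place: thian-4-yl in place of oxan-4-yl on an amine nitrogen. Among the measured compounds shown here, no measured step makes this kind of exchange. For the measured compounds named here, the steps that bear on it, a 1.5-fold higher number from compound 1 to compound 3 (0.17 log units; within the scatter) and a 5.4-fold lower number from compound 2 to compound 3 (0.73 log units; beyond the scatter), show that oxan-4-yl on this amine nitrogen stands close to benzyl and apart from cyclohexylmethyl. Compound 4 is therefore expected to show no step beyond the scatter, a 1.2-fold higher number from compound 3 to compound 4 (0.08 log units; within the scatter). The estimate for compound 4 is 35 nM, with a range from 12 nM to 100 nM.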

Compound 4, half-maximal inhibitory concentration: 54.7 nM
Compound 4: middle estimate off by 1.6-fold (0.19 log units), on the low side, within the range that was stated.
By their numbers in this assay, from the lowest: compounds 1, 3 and 4 (each within the scatter of the next, the first and the last beyond it); then compound 2.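

Placing thian-4-yl where oxan-4-yl stood on this amine nitrogen is tolerated, with a step that stays within the scatter (a 1.9-fold higher number from compound 3 to compound 4 (0.27 log units; within the scatter)). Thian-4-yl remains clear of cyclohexylmethyl (a 2.9-fold lower number from compound 2 to compound 4 (0.46 log units; beyond the scatter)), but unlike oxan-4-yl it no longer stands level with benzyl (a 2.7-fold higher number from compound 1 to compound 4 (0.43 log units; beyond the scatter)). No measurement here gives a reason for these differences. The compounds shown leave open how piperidin-4-yl on this amine nitrogen, or the sulfone form of thian-4-yl, would compare with these groups.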